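The source may hold more compounds than are shown below. What is called first, only, known or untested is meant among the compounds shown, and "the series" means these compounds.

Measured compounds:
compound 1 `N=C(NC(=N)NC1CCCC1)Nc1ccc(C(F)(F)F)cc1` — 1800 nM
compound 2 `CCN(C)C(=N)NC(=N)Nc1ccc(C(F)(F)F)cc1` — 4100 nM
compound 3 `CCN(CC)C(=N)NC(=N)Nc1ccc(F)c(F)c1` — 7800 nM

In a functional assay on A549 cells (Homo sapiens) for antiproliferative activity, read by MTT assay, with a stated time of 72 h (on this read-out lower numbers stand for stronger inhibition and higher numbers for weaker inhibition), compound 3 gives the highest number of the three; its gap to compound 2 is within the usual scatter, whereas its gap to compound 1 lies beyond it. Compound 4 `N=C(NC(=N)NC1CCCC1)Nc1ccc(F)c(F)c1` is not yet measured. It differs from compound 3 in one place: cyclopentylamino in place of diethylamino on a carbon with a double bond to nitrogen.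

Within the data shown here, one measured step bears on this change. It runs the other way round, from the cyclopentylamino group to a small open-chain dialkylamino group on the same carbon: a 2.3-fold higher number from compound 1 to compound 2 (0.36 log units; beyond the scatter). The change from compound 3 to compound 4 reinstates the cyclopentylamino group, so a step of comparable size in the opposite direction, towards a lower number in this assay, is the expectation, with the diethylamino group of compound 3 standing in for the ethyl(methyl)amino group of compound 2.

Compound 4 is therefore expected at about 3500 nM, in the range 1500 nM to 8000 nM, which corresponds to an estimated step of a 2.2-fold lower number from compound 3 to compound 4 (0.35 log units; beyond the scatter).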

Compound 4, half-maximal inhibitory concentration: 3500 nM
Beside the measured number, compound 4's estimate shows no gap at the digits printed; the measured number falls inside the stated range.
By their numbers in this assay, from the lowest: compounds 1, 4, 2 and 3 (each within the scatter of the next, the first and the last beyond it).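

In this assay, the swap on the carbon with a double bond to nitrogen now has a second reading on a different aryl substitution: a 2.2-fold lower number from compound 3 to compound 4 (0.35 log units; beyond the scatter), alongside a 2.3-fold higher number from compound 1 to compound 2 (0.36 log units; beyond the scatter). In both pairs the compound with cyclopentylamino gives the lower number, with no listed pair against this, so the effect is not confined to the trifluoromethyl compounds and holds with either diethylamino or ethyl(methyl)amino as the open-chain partner. No measurement on hand accounts for this step.

The change brings in a ring and a hydrogen-bond donor together, and these two compounds pairs cannot separate them. A pyrrolidin-1-yl group, with its ring and no donor, and an open-chain isopropylamino group, with a donor and no ring, would bear on that, while cyclohexylamino would extend the ring question.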